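A few compounds are considered here, and "the series" means these few. Any claim that something is new, unique, unknown or untested is made for them only; others in the source may bear on it.

Compound 1 `COC1=C(C)C(=O)/C(=C(O)/C=C/c2ccccc2OC)C(=O)C1(C)C` gives 4.1 ug/mL
Compound 2 `COC1=C(C)C(=O)/C(=C(O)/C=C/c2ccc(O)cc2)C(=O)C1(C)C` gives 14.8 ug/mL
Compound 3 `COC1=C(C)C(=O)/C(=C(O)/C=C/c2ccc(F)cc2)C(=O)C1(C)C` gives 3.6 ug/mL

These three numbers come from a functional assay on HCT-8 cells (Homo sapiens) for cytotoxicity (on this read-out lower numbers stand for an effect already at smaller amounts and higher numbers for an effect only at larger amounts of compound), and the compounds share one core. Compound 3, which carries a 4-fluorophenyl group, stands together with compound 1 at the lower end of the set, while compound 2 lies higher.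

The next compound is compound 4 `COC1=C(C)C(=O)/C(=C(O)/C=C/c2ccc(C)cc2)C(=O)C1(C)C` with methyl in place of fluoro on an aromatic carbon and the rest unchanged. For the measured compounds named here, three measured steps bear on this change. Two are modest and beyond the scatter, a 3.6-fold higher number from compound 1 to compound 2 (0.56 log units; beyond the scatter) and a 4.1-fold lower number from compound 2 to compound 3 (0.61 log units; beyond the scatter) and both involve the hydroxy group of compound 2. Compound 4 has no such group. The step that avoids it, a 1.1-fold lower number from compound 1 to compound 3 (0.06 log units; within the scatter) stays within the scatter.

No step beyond the scatter is therefore expected in this assay and the estimated outcome is a 1.3-fold higher number from compound 3 to compound 4 (0.10 log units; within the scatter) with no firm direction. Compound 4 is estimated at 4.5 ug/mL with 2.2 ug/mL to 9.5 ug/mL as the expected range.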

Compound 4, concentration for half-maximal effect: 4.1 ug/mL
Estimate against measurement, compound 4: 1.1-fold (0.04 log units) above; measured number inside the range.
By their numbers in this assay, from the lowest: compounds 3, 1 and 4 (each within the scatter of the next); then compound 2.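

In this assay, methyl and fluoro at this spot on the aromatic ring cannot be told apart (the change gives a 1.1-fold higher number from compound 3 to compound 4 (0.06 log units; within the scatter)). Methyl in place of hydroxy at the same spot gives a clear shift (a 3.6-fold lower number from compound 2 to compound 4 (0.56 log units; beyond the scatter)), so compound 2 now differs from two other compounds through a change at this one atom. The 4-methylphenyl group of compound 4 also matches the 2-methoxyphenyl group of compound 1 (no change at the digits printed from compound 1 to compound 4 (within the scatter)), so among these four compounds only compound 2, with its hydroxy group, stands apart.

No measurement shown explains why the hydroxy group behaves differently from the other groups. From the compounds shown here alone, it also remains open whether an amine, a carboxylic acid or a longer chain at this spot would match compound 4 or compound 2.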